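Removing the sulfanyl side chain from compound 3

The source may report more compounds than this note shows. Statements on the series, on what has been measured and on what is new or still open speak of the compounds shown alone.

Values in an ADME assay on GES1 cells (Homo sapiens) for inhibition, read by MTT assay, with a stated time of 72 h; on this read-out higher numbers stand for weaker inhibition and lower numbers for stronger inhibition:
- compound 1 `Cc1cc(Nc2cc(-c3ccccc3)[nH]n2)n2nc(SCCc3ccccc3)nc2n1`: 37400 nM
- compound 2 `Cc1cc(Nc2cc(-c3ccccc3)[nH]n2)n2nc(SCc3ccc([N+](=O)[O-])cc3)nc2n1`: 43600 nM
- compound 3 `Cc1ccc(CSc2nc3nc(C)cc(Nc4cc(-c5ccccc5)[nH]n4)n3n2)cc1`: 36200 nM

The three numbers lie close together. Compound 3, at 36200 nM, stands level with the other two, since all of its steps stay within the scatter. The step to it from the first is a 1.0-fold lower number from compound 1 to compound 3 (0.01 log units; within the scatter), and the step from the second is a 1.2-fold lower number from compound 2 to compound 3 (0.08 log units; within the scatter). The remaining pair agrees, with a 1.2-fold higher number from compound 1 to compound 2 (0.07 log units; within the scatter).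

Compound 4 `Cc1cc(Nc2cc(-c3ccccc3)[nH]n2)n2ncnc2n1` has not yet been measured. The change leading to it is hydrogen in place of (4-methylbenzyl)sulfanyl on an aromatic carbon, so the whole side chain on sulfur goes and only hydrogen remains.

The measured steps bear on this only in part. Among the compounds with values here, each of them alters the aromatic end of the group on sulfur, and none removes that group, so the data hold no direct precedent. Compound 3 offers only a 1.0-fold lower number from compound 1 to compound 3 (0.01 log units; within the scatter) and a 1.2-fold lower number from compound 2 to compound 3 (0.08 log units; within the scatter) as a guide, which argues against expecting a large step in this assay. A step no larger than the scatter is expected, if anything toward a higher number. The expected step is a 1.4-fold higher number from compound 3 to compound 4 (0.14 log units; within the scatter). Compound 4 is estimated at 50000 nM, with an expected range from 25000 nM to 100000 nM.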

Compound 4, half-maximal inhibitory concentration: > 50000 nM
Compound 4: no number, only a limit (the forecaster's own chance of this, stated with the estimate: 25%); the middle value sits exactly at the limit.
By their numbers in this assay, from the lowest: compounds 3, 1 and 2 (each within the scatter of the next). At a limit, above all of these: compound 4.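

In this assay, compound 4, which keeps only hydrogen on the aromatic carbon between two ring nitrogen atoms, gives a limit of the assay and not a number: the limit of > 50000 nM in this assay, at which 1 of the 4 values shown sits.

Against the three sulfanyl compounds, this limit yields only floors: an at least 1.3-fold higher number from compound 3 to compound 4 (0.14 log units; that floor lies within the scatter), an at least 1.3-fold higher number from compound 1 to compound 4 (0.12 log units; that floor lies within the scatter) and an at least 1.1-fold higher number from compound 2 to compound 4 (0.05 log units; that floor lies within the scatter). The earlier compounds shown here altered only the aromatic end of the group on sulfur, whereas this change removes the whole side chain, and it gives no sign of a move to a lower number, although floors of this size cannot show whether the true step lies within the scatter or beyond it.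

The compounds shown leave open how much of the side chain counts in this read-out, and whether a small group on the same carbon, such as methylsulfanyl or an amine, would stand with compound 1, compound 2 and compound 3 or would also reach the limit. As far as these compounds go, they also leave open how far the true value of compound 4 lies from its limit, so the full size of this change remains unknown.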